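The source may hold more compounds than are shown below. What is called first, only, known or untested is meant among the compounds shown, and "the series" means these compounds.

Compound 1, `CCCCCCCCn1cc(COC2(C(F)(F)F)Oc3ccccc3C=C2C(=O)OCC)nn1`. In a functional assay on HeLa cells (Homo sapiens) for inhibition, read by MTT assay, with a stated time of 24 h (a higher number here means a weaker inhibitor, a lower number a stronger inhibitor), compound 1 gives > 150000 nM, which is a limit of the assay and not a number.
Compound 2, `CCOC(=O)C1=Cc2ccccc2OC1(OCc1cn(CC(=O)Nc2ccccc2Br)nn1)C(F)(F)F`. In this assay compound 2 gives > 150000 nM, again a limit of the assay.

Compound 2 therefore stands only at a limit, as the limit of > 150000 nM in this assay, at which 2 of the 2 values shown sit, shows, and the step that the two limits leave unreadable from compound 1 to compound 2 cannot be read. Compound 3, `CCOC(=O)C1=Cc2ccccc2OC1(OCc1cn(-c2ccc(F)c([N+](=O)[O-])c2)nn1)C(F)(F)F`, differs from compound 2 by 4-fluoro-3-nitrophenyl in place of ((2-bromophenyl)carbamoyl)methyl on an aromatic nitrogen. Within the data shown here, the single measured step offers no readable size, so no step beyond the scatter is expected. Compound 3 is estimated at 150000 nM, between 50000 nM and 300000 nM, an expected step of a number no higher from compound 2 to compound 3 (the limit leaves the size open).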

Compound 3, half-maximal inhibitory concentration: 15600 nM
Estimate against measurement, compound 3: 9.6-fold (0.98 log units) above, and the stated range ends above it.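

At this aromatic nitrogen, the group can clearly change the result in this assay: 4-fluoro-3-nitrophenyl brings an at least 9.6-fold lower number from compound 2 to compound 3 (0.98 log units; beyond the scatter) when it replaces ((2-bromophenyl)carbamoyl)methyl, and an at least 9.6-fold lower number from compound 1 to compound 3 (0.98 log units; beyond the scatter) when it replaces octyl. The step between compound 1 and compound 2 cannot be read, and the full size of both new steps stays open because their starting values are limits, not numbers: the limit of > 150000 nM in this assay, at which 2 of the 3 values shown sit.

On these data alone, it remains open whether any phenyl on this nitrogen gives the lower number or whether the fluoro and nitro groups are needed. Plain phenyl, or an amine in place of the nitro group, would help separate these possibilities.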